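Bromo-to-hydrogen swap in tetrasubstituted bis-chalcone phenols

This account rests on a few compounds, and the source may have more. Where it says the series, first, only, none or still open, it means among the compounds named here.

The measured compounds:
Compound 1, `Cc1cc(O)c(C(=O)/C=C/c2ccc(OCc3ccccc3)cc2)c(-c2ccccc2)c1C(=O)/C=C/c1ccc(OCc2ccccc2)cc1`, gives 10000 nM in a functional assay on MDA-MB-231 cells (Homo sapiens) for cytotoxicity, read by MTT assay, with a stated time of 24 h; a lower number here means a stronger inhibitor, a higher number a weaker inhibitor.
Compound 2, `COc1ccc(/C=C/C(=O)c2c(C)cc(O)c(C(=O)/C=C/c3ccc(OC)cc3)c2-c2ccc(Br)cc2)cc1`, is reported in this assay as "not active" (no number reported), with no number given.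
Compound 3, `Cc1cc(O)c(C(=O)/C=C/c2ccc(OCc3ccccc3)cc2)c(-c2ccc(Br)cc2)c1C(=O)/C=C/c1ccc(OCc2ccccc2)cc1`, gives 20000 nM in this assay.

From compound 3 to compound 1 the change is hydrogen in place of bromo on an aromatic carbon, and the step it made is a 2.0-fold lower number from compound 3 to compound 1 (0.30 log units; within the scatter). Compound 4, `COc1ccc(/C=C/C(=O)c2c(C)cc(O)c(C(=O)/C=C/c3ccc(OC)cc3)c2-c2ccccc2)cc1`, is not yet measured; it arises from compound 2 by the same change, (hydrogen in place of bromo on an aromatic carbon). The difference between the core of compound 2 and the core of compound 3 is not broken down here. Among the measured compounds shown here, since compound 2 is reported as not active without a number, the only guide to the size of the step from compound 2 to compound 4 in this assay is the step from compound 3 to compound 1, which lies within the scatter, so a small step is expected and compound 4 is expected to remain weak. Compound 4 is estimated at 30000 nM, between 8000 nM and 100000 nM.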

Compound 4, half-maximal inhibitory concentration: "not active" (no number reported)
Nothing numeric was reported for compound 4; there is nothing to compare the estimate with.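

In this assay compound 2 reads "not active" (no number reported) and compound 4 reads "not active" (no number reported), so no step can be read between them, and no evidence bears on this result. The compounds shown leave open how far the change from 4-bromophenyl to phenyl shifts potency on the core of compound 2.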